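This account rests on a few compounds, and the source may have more. Where it says the series, first, only, none or still open, it means among the compounds named here.

Working notes on a small series sharing one core, read in a functional assay on HCT-116 cells (Homo sapiens) for inhibition, read by MTT assay, with a stated time of 72 h; on this read-out higher numbers stand for weaker inhibition and lower numbers for stronger inhibition.

Compound 1 `O=C1Nc2ccc(Br)cc2/C1=N/NC(=S)N1CCN(c2ccccc2)CC1` gives 10400 nM in this assay. Compound 2 `O=C1Nc2ccc(Cl)cc2/C1=N/NC(=S)N1CCN(c2ccccc2)CC1` differs from compound 1 by chloro in place of bromo on an aromatic carbon. In this assay compound 2 gives 3490 nM; the step is a 3.0-fold lower number from compound 1 to compound 2 (0.47 log units; beyond the scatter). Compound 3 `O=C1Nc2cc(Br)ccc2/C1=N/NC(=S)N1CCN(c2ccccc2)CC1` has the same atoms as compound 1, joined differently; the difference between the two cores is not broken down here. In this assay compound 3 gives 14500 nM. The gap between compound 3 and compound 1 lies within the scatter, the gap between compound 3 and compound 2 lies beyond it.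

Compound 4 `O=C1Nc2cc(Cl)ccc2/C1=N/NC(=S)N1CCN(c2ccccc2)CC1` is not yet measured. It differs from compound 3 by chloro in place of bromo on an aromatic carbon, which is the same change as that made from compound 1 to compound 2, with the same surroundings described at the place of the change. This change has been seen once in the series, on the core of compound 1. Within the data shown here, the step expected from compound 3 to compound 4 in this assay is a 2.6-fold lower number from compound 3 to compound 4 (0.42 log units; beyond the scatter), set beside the earlier one because a 3.0-fold lower number from compound 1 to compound 2 (0.47 log units; beyond the scatter) is the only precedent, and the core of compound 3 being different widens the uncertainty. Compound 4 is therefore expected to give about 5500 nM in this assay. The expected range for compound 4 runs from 2000 nM to 15000 nM.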

Compound 4, half-maximal inhibitory concentration: 17900 nM
Compound 4: middle estimate off by 3.3-fold (0.51 log units), on the low side; the whole stated range lies below it.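

In this assay, chloro in place of bromo on an aromatic carbon gives a 1.2-fold higher number from compound 3 to compound 4 (0.09 log units; within the scatter), so this pair shows no gain that can be told from the scatter, unlike the pair on the core of compound 1. Among these compounds, the change therefore does not carry over with the same size from one core to the other: the same change on two cores in this assay, a 3.0-fold lower number (0.47 log units; beyond the scatter) from compound 1 to compound 2 and a 1.2-fold higher number (0.09 log units; within the scatter) from compound 3 to compound 4, 3.7-fold (0.57 log units) apart, beyond the scatter of two such steps This shows that the outcome of this halogen exchange depends on the core within these four compounds, but with only one pair on each core it gives no general rule, does not say which feature of the cores is responsible, and does not show that the exchange would be without consequence in other members.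

On these data alone, it remains open whether fluoro, iodo, methyl or methoxy on the same aromatic carbon would follow the pattern of the core of compound 1 or that of the core of compound 3. Also open, as far as these compounds go, is whether the difference between the two cores would persist if the halogen were replaced by a carboxylic acid or an amine.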